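The compounds below may be only part of what the source reports. "The series", "measured", "known", "first", "only" and "open" are said of these compounds alone.

Of the compounds shown here, three sharing one core have been measured in a functional assay on WI-38 cells (Homo sapiens) for inhibition; a lower number here means a stronger inhibitor, a higher number a weaker inhibitor. Compound 1 `CC(=O)OCCOn1cnc2c(Cl)nc(N)nc21` carries an amino group and a chloro group on that core. In this assay compound 1 gives only a limit of the assay, > 500000 nM. Compound 2 `CC(=O)OCCOn1cnc2c(Cl)nc(I)nc21` differs from compound 1 by iodo in place of amino on an aromatic carbon; in this assay compound 2 gives 63100 nM. That change is an at least 7.9-fold lower number from compound 1 to compound 2 (0.89 log units; beyond the scatter). Compound 3 `CC(=O)OC(C)n1cnc2c(Cl)nc(F)nc21` differs from both others in more than one place; in this assay compound 3 gives 100000 nM. For compound 1 itself only the limit of > 500000 nM in this assay, at which 1 of the 3 values shown sits, is known, so its standing among the three is a floor rather than a number.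

Compound 4 `CC(=O)OCCOn1cnc2c(S)nc(N)nc21` has not been measured. It differs from compound 1 by sulfanyl in place of chloro on an aromatic carbon. Among the compounds with values here, no measured step touches this position: the move from compound 1 to compound 2 alters a different group, so it shows only that a single change on this core can shift the number by an at least 7.9-fold lower number from compound 1 to compound 2 (0.89 log units; beyond the scatter). With nothing closer to lean on, the expected step is an at least 1.2-fold lower number from compound 1 to compound 4 (0.09 log units; that floor lies within the scatter), with the number likely staying close to the region of the limit. Compound 4 is therefore estimated at 400000 nM in this assay, between 80000 nM and 2000000 nM.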

Compound 4, half-maximal inhibitory concentration: > 500000 nM
Compound 4: only a limit was reported; the forecaster's own chance of this, stated with the estimate: 55%; middle value at least 1.2-fold (0.09 log units) away from the limit.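

In this assay, compound 1 and compound 4 both stand at a limit of the assay rather than at a number, so the step of sulfanyl in place of chloro cannot be read: the limit of > 500000 nM in this assay, at which 2 of the 4 values shown sit. The compounds shown leave open whether this swap changes inhibition at all, including on a version of the core that carries iodo instead of amino.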